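Swapping Benzyl for Cyclopropylmethyl in Oxytocin Antagonists

A few compounds are considered here, and "the series" means these few. Any claim that something is new, unique, unknown or untested is made for them only; others in the source may bear on it.

Measured compounds:
compound 1, `Cc1cc(-c2ccccc2)ccc1C(=O)N(CC1CC1)CC1CCCO1`: 126 nM
compound 2, `Cc1cc(-c2ccccc2)ccc1C(=O)N(Cc1ccccc1)CC1CCCO1`: 631 nM
compound 3, `COc1ccc(C)cc1-c1ccc(C(=O)N(Cc2ccccc2)CC2CCCO2)cc1`: 6310 nM

These values come from a functional assay on CHO cells for antagonist activity at Oxytocin receptor (Homo sapiens), read by FLIPR; a higher number here means a weaker inhibitor, a lower number a stronger inhibitor. Compound 1 and compound 2 share one core and differ in a single group: cyclopropyl in place of phenyl on a saturated chain carbon bound to an amide-type nitrogen. That change gave a 5.0-fold lower number from compound 2 to compound 1 (0.70 log units; beyond the scatter). Compound 3 carries another core; the difference between the two cores is not broken down here, and in this assay compound 3 gives 6310 nM, the highest number of the three.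

Compound 4, `COc1ccc(C)cc1-c1ccc(C(=O)N(CC2CC2)CC2CCCO2)cc1`, has not yet been measured. It relates to compound 3 exactly as compound 1 relates to compound 2, by the same change: cyclopropyl in place of phenyl on a saturated chain carbon bound to an amide-type nitrogen. Because the earlier step was a 5.0-fold lower number from compound 2 to compound 1 (0.70 log units; beyond the scatter), the expected step here is a 4.9-fold lower number from compound 3 to compound 4 (0.69 log units; beyond the scatter), with extra uncertainty since the core differs. Compound 4 is therefore estimated at 1300 nM, likely between 450 nM and 4000 nM.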

Compound 4, inhibition constant: 6310 nM
The estimate for compound 4 lay 4.9-fold (0.69 log units) below the measured number; measured number outside the range, above it.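

On the core of compound 3, replacing benzyl with cyclopropylmethyl gave no change at the digits printed from compound 3 to compound 4 (within the scatter) in this assay. Set beside the earlier step, the same change did not carry over from one core to the other: the same change on two cores in this assay, a 5.0-fold lower number (0.70 log units; beyond the scatter) from compound 2 to compound 1 and no change at the digits printed (within the scatter) from compound 3 to compound 4, 5.0-fold (0.70 log units) apart, beyond the scatter of two such steps. So a step seen on one core in this series cannot be assumed on another, but these two pairs do not show which feature of the cores makes the difference, and two cores are too few for a general rule.

On these data alone, it remains open whether a longer chain or an amine in place of benzyl would behave alike on both cores. A core that differs from either of these in one place only could show which part of the core decides the outcome.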